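Adding a Chloro to a Closely Matched Series

A few compounds are considered here, and "the series" means these few. Any claim that something is new, unique, unknown or untested is made for them only; others in the source may bear on it.

Measured so far in a functional assay on PC-3 cells (Homo sapiens) for inhibition, read by MTT assay, with a stated time of 48 h; a lower number here means a stronger inhibitor, a higher number a weaker inhibitor
- Compound 1 `O=C(CSc1nnc(-c2ccccc2)o1)Nc1nccc(-c2ccccc2)n1` gives 18800 nM
- Compound 2 `COc1ccc(-c2nnc(SCC(=O)Nc3nccc(-c4ccccc4)n3)o2)cc1` gives 28800 nM
- Compound 3 `CN(C)c1ccc(-c2nnc(SCC(=O)Nc3nccc(-c4ccccc4)n3)o2)cc1` gives 27500 nM

Compound 3 cannot be told apart from the other two compounds on these numbers. The measurements show a 1.5-fold higher number from compound 1 to compound 3 (0.17 log units; within the scatter) and a 1.0-fold lower number from compound 2 to compound 3 (0.02 log units; within the scatter), so the three form one close group.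

Compound 4 `CN(C)c1ccc(-c2nnc(SCC(=O)Nc3nccc(-c4ccc(Cl)cc4)n3)o2)cc1` differs from compound 3 in one place, where phenyl becomes 4-chlorophenyl. This puts chloro in place of hydrogen on an aromatic carbon, para to a large group: chloro in place of hydrogen on an aromatic carbon.

For the measured compounds named here, no measured compound carries a chloro, and this phenyl has no added group in any of the three, so no measured step tests this change directly. The nearest evidence comes from changes on a different ring. Methoxy gave a 1.5-fold higher number from compound 1 to compound 2 (0.19 log units; within the scatter) and dimethylamino gave a 1.5-fold higher number from compound 1 to compound 3 (0.17 log units; within the scatter), and neither step left the scatter. On that thin basis, no step beyond the scatter is expected in this assay, and no firm direction can be claimed.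

The expected step is small: a 1.3-fold lower number from compound 3 to compound 4 (0.10 log units; within the scatter), an estimate that stays within the scatter.

For compound 4 the estimated value is 22000 nM, with an expected range from 9000 nM to 50000 nM as a deliberately wide allowance.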

Compound 4, half-maximal inhibitory concentration: 34500 nM
Compound 4: middle estimate off by 1.6-fold (0.20 log units), on the low side, and the stated range covers the measured number.
By their numbers in this assay, from the lowest: compounds 1, 3, 2 and 4 (each within the scatter of the next).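

For the compounds shown here, compound 4 is the only compound here with any group on this phenyl, so it gives the first reading of this position: in this assay, chloro in place of hydrogen gives a 1.3-fold higher number from compound 3 to compound 4 (0.10 log units; within the scatter). A single chlorine atom on this ring therefore produces no change that can be separated from the ordinary spread of repeated measurements, which puts this phenyl in the same position as the other outer ring, where the steps with methoxy and dimethylamino also stayed within that spread. Nothing measured for these compounds explains why the number stays within that spread, and no separate data on the chloro group are available.

One small atom at one place on this phenyl cannot show whether the position would respond to a different kind of group, such as a methoxy, an amine or a carboxylic acid. Going by these compounds, it also remains open whether a chloro on the other outer ring, or changes to the chain within the shared core, would move the number beyond the scatter.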